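This account rests on a few compounds, and the source may have more. Where it says the series, first, only, none or still open, it means among the compounds named here.

Measured in a functional assay on T-24 cells (Homo sapiens) for cytotoxicity, read by MTT assay, with a stated time of 24 h; a higher number here means a weaker inhibitor, a lower number a stronger inhibitor:
- compound 1 `C=C1C(=O)[C@H]2C[C@]1(O)CC1=C2[C@]2(C)CCCC(C)(C)[C@H]2CC1` gives 2300 nM
- compound 2 `C=C1C(=O)[C@H]2C[C@@H]1CC1=C2[C@]2(C)CCC[C@](C)(CO)[C@H]2CC1` gives 49100 nM
- compound 3 `C[C@@H]1C(=O)[C@H]2C[C@]1(O)CC1=C2[C@]2(C)CCC[C@](C)(CO)[C@H]2CC1` gives > 50000 nM, which is a limit of the assay, not a number

Compound 3 stands at the limit of > 50000 nM in this assay, at which 1 of the 3 values shown sits, so only a limit is known for it. Compound 1 is the only one of the three with a value in the lower part of the range; compound 2 reads far higher than compound 1.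

Compound 4 `C[C@@H]1C(=O)[C@H]2C[C@]1(O)CC1=C2[C@]2(C)CCC[C@@](C)(CO)[C@H]2CC1` is the next step: the two compounds have the same atoms and bonds and differ only in configuration as drawn: 1 of 6 stereo elements differ; a stereocentre at a saturated ring carbon is drawn S in compound 3 and R in compound 4. Among the measured compounds shown here, no measured pair shows what such a change does here, so a step of a number no higher from compound 3 to compound 4 (the limit leaves the size open) is expected, none beyond the scatter. Compound 4 is estimated at 50000 nM, within 15000 nM to 150000 nM, and a limit again is thought likely.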

Compound 4, half-maximal inhibitory concentration: > 50000 nM
Compound 4: no number, only a limit (the forecaster's own chance of this, stated with the estimate: 60%); the middle value lies on the limit itself.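

No step can be read between compound 3 and compound 4, because both give no number, only a limit: the limit of > 50000 nM in this assay, at which 2 of the 4 values shown sit. From the compounds shown here alone, whether the configuration at that saturated ring carbon changes potency anywhere under that limit stays open.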